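The source may report more compounds than this note shows. Statements on the series, on what has been measured and on what is new or still open speak of the compounds shown alone.

Compound 1 `Nc1cc(N)c2nc(-c3ccccc3)c(Oc3ccc(Cl)c(Cl)c3)nc2c1` serves as the reference point of this small set. In a functional assay on A549 cells (Homo sapiens) for inhibition, read by sulforhodamine B assay, with a stated time of 48 h (a lower number here means that less compound is tolerated, a higher number that more compound is tolerated), compound 1 gives only a limit, < 100000 nM, and not a number. Compound 2 `CCOC(=O)[C@H](CCC(=O)O)NC(=O)c1ccc(CNc2nc3cc(N)cc(N)c3nc2-c2ccccc2)cc1` likewise returns a limit in this assay, namely < 100000 nM. Compound 3 `COc1cc(CNc2nc3cc(N)cc(N)c3nc2-c2ccccc2)cc(OC)c1OC` also ends at a limit in this assay, namely < 50200 nM. Among the measured compounds shown here, the three values shown therefore show nothing beyond the limit of < 100000 nM in this assay, at which 2 of the 3 values shown sit, and (the limit of < 50200 nM in this assay, at which 1 of the 3 values shown sits); no measured step between any pair is available, and compound 1 cannot be placed relative to the others in any direction. Compound 4 `Nc1cc(N)c2nc(-c3ccccc3)c(Sc3ccc(F)cc3)nc2c1` differs from compound 1 in one place: (4-fluorophenyl)sulfanyl in place of 3,4-dichlorophenoxy on an aromatic carbon. For compound 4 the expected step is a step that the limit leaves unreadable from compound 1 to compound 4 in this assay, with the honest statement that it may amount to nothing beyond the scatter or to a moderate shift either way. For compound 4 the estimate in this assay is 30000 nM, with a range from 5000 nM to 100000 nM, and a fair chance that only a limit is reported once more.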

Compound 4, concentration lethal to 50% of the cells: 70800 nM
The estimate for compound 4 lay 2.4-fold (0.37 log units) below the measured number; measured number inside the range.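

Among the compounds shown here, compound 1 remains a limit in this assay, < 100000 nM, and not a number, so no step to compound 4 can be read. The compounds shown leave open whether (4-fluorophenyl)sulfanyl in place of 3,4-dichlorophenoxy on the shared core shifts the value at all, and in which direction.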